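Morpholine Amide Variant of an Oxytocin Receptor Ligand

The source may report more compounds than this note shows. Statements on the series, on what has been measured and on what is new or still open speak of the compounds shown alone.

Compound 2, `Cc1nc([C@H](C(=O)N(C)CCO)N2C(=O)[C@@H](C3Cc4ccccc4C3)NC(=O)[C@H]2CC(C)C)co1`, was tested in an assay on isolated protein for binding affinity to Oxytocin receptor (Homo sapiens) (a lower number here means a stronger inhibitor, a higher number a weaker inhibitor), where compound 2 gives 1.26 nM. Compound 1, `CC(C)C[C@@H]1C(=O)N[C@H](C2Cc3ccccc3C2)C(=O)N1[C@@H](C(=O)NC(C)C)c1ccc(Br)o1`, gives 0.794 nM in this assay; the two numbers lie within the usual scatter of each other, so no difference between them can be read. Compound 3, `Cc1nc([C@H](C(=O)N2CCOCC2)N2C(=O)[C@@H](C3Cc4ccccc4C3)NC(=O)[C@H]2CC(C)C)co1`, is not yet measured. It differs from compound 2 by morpholin-4-yl in place of (2-hydroxyethyl)(methyl)amino on a carbonyl carbon. Among the measured compounds shown here, no measured pair shows what such a change does here, so the expected size of the step is a 1.2-fold higher number from compound 2 to compound 3 (0.08 log units; within the scatter), nothing beyond the scatter. Compound 3 is expected to give 1.5 nM, within a range from 0.5 nM to 5 nM.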

Compound 3, inhibition constant in the Oxytocin receptor assay: 2 nM
For compound 3 the middle estimate is 1.3-fold (0.12 log units) below the measured one; the range from low to high includes it.
By their numbers in the Oxytocin receptor assay, from the lowest: compounds 1, 2 and 3 (each within the scatter of the next, the first and the last beyond it).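

In the Oxytocin receptor assay, morpholin-4-yl in place of (2-hydroxyethyl)(methyl)amino on a carbonyl carbon gives a 1.6-fold higher number from compound 2 to compound 3 (0.20 log units; within the scatter). Among the compounds shown here, this is the first matched pair at this position, and it shows that a ring without a hydrogen-bond donor can replace the open chain with no readable change in this read-out. In a physicochemical assay for solubility (on this read-out lower numbers stand for lower solubility and higher numbers for higher solubility), compound 2 gives > 220 ug/mL as a limit of the assay. In the physicochemical assay compound 3 gives > 220 ug/mL as a limit of the assay. In the physicochemical assay, the same step cannot be read, since compound 2 and compound 3 both sit at a limit of the assay: the limit of > 220 ug/mL in the physicochemical assay, at which 2 of the 2 values shown sit.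

Still open, from the compounds shown here alone, is what a piperidin-1-yl group, which has no ring oxygen, or a piperazin-1-yl group, with a second ring nitrogen, would do at this carbonyl carbon in the Oxytocin receptor assay.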